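The source may report more compounds than this note shows. Statements on the series, on what has been measured and on what is new or still open speak of the compounds shown alone.

Two measured compounds frame the series. Compound 1 `FC(F)(F)c1ccc2[nH]c(-c3ccccc3)nc2c1` and compound 2 `O=[N+]([O-])c1ccc2nc(-c3ccccc3Cl)[nH]c2c1` share the core; in a functional assay for antagonist activity at Neuropeptides B/W receptor type 1 (Homo sapiens), read by cAMP accumulation (on this read-out lower numbers stand for stronger inhibition and higher numbers for weaker inhibition), compound 1 gives 1200 nM, and compound 2 gives 10700 nM. Compound 1 thus gives the lower of the two numbers. Compound 3 `FC(F)(F)c1ccc2[nH]c(-c3ccc(-c4ccoc4)cc3)nc2c1` differs from compound 1 by furan-3-yl in place of hydrogen on an aromatic carbon. Going by the values given here, no comparable step exists among the measured compounds, so the size is uncertain; a small shift toward a lower number, not clearly beyond the scatter, is expected, as a 1.5-fold lower number from compound 1 to compound 3 (0.18 log units; within the scatter). Compound 3 is estimated at 800 nM, with a range from 250 nM to 3000 nM.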

Compound 3, half-maximal inhibitory concentration: 1190 nM
Beside the measured number, compound 3's estimate is 1.5-fold (0.17 log units) below it, within the range that was stated.
By their numbers in this assay, from the lowest: compounds 3 and 1 (each within the scatter of the next); then compound 2.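

Furan-3-yl in place of hydrogen gives a 1.0-fold lower number from compound 1 to compound 3 (0.00 log units; within the scatter) in this assay, the first reading at this position, on an aromatic carbon para to a large group. This position therefore carries a five-membered aromatic ring without a change beyond the scatter, so the added heavy atoms leave this read-out where compound 1 stands. From the compounds shown here alone, whether an amine, a carboxylic acid or a longer chain at this place would give a step beyond the scatter remains open. No supporting data bear on this flat step.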